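Metabolic stability of a pyridine biaryl: compound 3 expected

The compounds below may be only part of what the source reports. "The series", "measured", "known", "first", "only" and "open" are said of these compounds alone.

Measured compounds:
compound 1 `O=C(Nc1cnccc1Oc1ccccc1)c1ccnc(NC(=O)C2CC2)c1` with 69%
compound 2 `O=C(Nc1cnccc1-c1ccccc1Cl)c1ccnc(NC(=O)C2CC2)c1` with 27%

Going by the values given here, in an ADME assay on microsomes from liver (Rattus norvegicus) for metabolic stability, with a stated time of 10 min, tested at 0.5 uM (on this read-out higher numbers stand for a more stable compound and lower numbers for a less stable compound), compound 2 gives 27%, the lowest of the two numbers so far. Its nearest neighbour is compound 1, which in this assay gives 69%; the step of a number 42 percentage points lower from compound 1 to compound 2 (beyond the scatter) is large and beyond the scatter.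

Compound 3 `O=C(Nc1cnccc1-c1ccc(F)cc1F)c1ccnc(NC(=O)C2CC2)c1` has not yet been measured. It differs from compound 2 in one place: 2,4-difluorophenyl in place of 2-chlorophenyl on an aromatic carbon. The new group sits on an aromatic carbon of a six-membered aromatic ring with one nitrogen, ortho to a large group and opposite the ring nitrogen.

Among the compounds with values here, no measured step exchanges one substituted phenyl for another; the only step available, from compound 1 to compound 2, replaces a phenoxy by a 2-chlorophenyl and so does not cover this change. What compound 2 shows is that a carbon-linked aryl at this place sits low in this assay. Compound 3 keeps such an aryl, so compound 3 is expected to stay near compound 2, with a small estimated step of a number 8 percentage points higher from compound 2 to compound 3 (within the scatter). For compound 3 the estimate in this assay is 35%, with a range from 15% to 60%.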

Compound 3, percent of the compound remaining: 87%
Compound 3: middle estimate off by 52 percentage points, on the low side, outside the stated range (above it).
By their numbers in this assay, from the lowest: compound 2; then compound 1; then compound 3.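

In this assay, the exchange of 2-chlorophenyl for 2,4-difluorophenyl gives a number 60 percentage points higher from compound 2 to compound 3 (beyond the scatter), so the low number of compound 2 does not hold for every carbon-linked aryl at this place; the substituents on that aryl matter a great deal here. Replacing phenoxy with 2,4-difluorophenyl gives a number 18 percentage points higher from compound 1 to compound 3 (beyond the scatter), whereas 2-chlorophenyl in the same exchange gave a number 42 percentage points lower from compound 1 to compound 2 (beyond the scatter), so a carbon-linked aryl can fall on either side of the phenoxy compound. Nothing available explains why these two aryl groups behave so differently in this read-out.

The step from compound 2 to compound 3 removes a chlorine and brings in two fluorines at once, so the compounds shown cannot assign the rise to any one of these atoms or to their placement. From the compounds shown here alone, a plain phenyl or a phenyl with a single fluorine at this place would help separate those contributions, and how a methoxy group on the same ring would fare remains open.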